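The compounds below may be only part of what the source reports. "The series", "measured", "known", "first", "only" and "open" are said of these compounds alone.

Values measured so far in an ADME assay on a cell-free system (plasma, Homo sapiens), with a stated time of 30 min; a lower number here means that less of the compound is left, a higher number that more of the compound is left

- compound 1 (`COc1ccccc1C(=O)N[C@]1(OC)C(=O)N2C(C(=O)OC(c3ccccc3)c3ccccc3)=C(CSc3nnnn3C)CO[C@@H]21`) gives 73%
- compound 2 (`COc1ccccc1C(=O)N[C@]1(OC)C(=O)N2C(C(=O)OCc3ccc(C(=O)O)cc3)=C(CSc3nnnn3C)CO[C@@H]21`) gives 26%
- compound 3 (`CCCOc1ccccc1C(=O)N[C@]1(OC)C(=O)N2C(C(=O)OCc3ccc(C(=O)O)cc3)=C(CSc3nnnn3C)CO[C@@H]21`) gives 26%

In this assay compound 3 stands level with compound 2 at the digits shown. Together these two hold the lowest of the three numbers, and compound 1 lies above them both, beyond the scatter.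

The next compound, compound 4 (`CO[C@@]1(NC(=O)c2ccccc2OC(C)C)C(=O)N2C(C(=O)OCc3ccc(C(=O)O)cc3)=C(CSc3nnnn3C)CO[C@@H]21`), has the same atoms as compound 3, joined differently (isopropyl in place of propyl on an oxygen on an aromatic ring). In words, this is isopropyl in place of propyl on an oxygen on an aromatic ring, or propoxy to isopropoxy.

Going by the values given here, only one measured step touches this chain: ethyl in place of hydrogen on a saturated chain carbon bound to an oxygen on an aromatic ring (no change at the digits printed from compound 2 to compound 3 (within the scatter)). Among the compounds with values here, compound 1 offers no step at this chain, and no compound with isopropyl here has been measured, so the guide is thin. Going by that single step to compound 3 (no change at the digits printed from compound 2 to compound 3 (within the scatter)), no shift beyond the scatter is expected in this assay for the new compound. The expected step is small in either direction (no change at the digits printed from compound 3 to compound 4 (within the scatter)). For compound 4 the estimated value is 26% with an expected range from 14% to 38% as its limits.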

Compound 4, percent of the compound remaining: 42%
Beside the measured number, compound 4's estimate is 16 percentage points below it, and the stated range ends below it.
By their numbers in this assay, from the lowest: compounds 2 and 3 (each within the scatter of the next); then compound 4; then compound 1.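

In this assay, the arrangement of the chain on this oxygen matters, not just its atom count: propyl and isopropyl have the same atoms, yet the change from one to the other gives a number 16 percentage points higher from compound 3 to compound 4 (beyond the scatter) in the percent of compound remaining. Measured from the methyl group, isopropyl gives a number 16 percentage points higher from compound 2 to compound 4 (beyond the scatter), whereas propyl gives no change at the digits printed from compound 2 to compound 3 (within the scatter), so among these three compounds only the branched chain moves the number beyond the scatter. The data shown offer no measurement that accounts for this difference between the two chains.

As far as these compounds go, one branched chain is a narrow basis, so it remains open whether the same rise would appear with other groups on this oxygen, such as cyclopropyl or tert-butyl, or whether ethyl would behave like methyl and propyl or like isopropyl. From the compounds shown here alone, it is also open whether isopropyl would give a similar step on the ester of compound 1, which has a higher number than the other compounds and carries methyl on this oxygen.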